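A few compounds are considered here, and "the series" means these few. Any claim that something is new, unique, unknown or untested is made for them only; others in the source may bear on it.

Series notes. Compound 1 `Cc1cccc(NNS(=O)(=O)c2ccc(C(=O)NCC(=O)O)cc2)c1` is the reference point: in an assay on HeLa cells for inhibition of Indoleamine 2,3-dioxygenase 1 (Homo sapiens), read by spectrophotometry, with a stated time of 24 h (on this read-out lower numbers stand for an effect already at smaller amounts and higher numbers for an effect only at larger amounts of compound), compound 1 gives 271 nM. Compound 2 `Cc1cccc(NNS(=O)(=O)c2ccc(S(C)(=O)=O)cc2)c1` differs from it only by methylsulfonyl in place of (carboxymethyl)carbamoyl, and in this assay compound 2 gives 7850 nM. For the measured compounds named here, this is the only single-point step with both ends measured, and it is large: a 29-fold higher number from compound 1 to compound 2 (1.46 log units; beyond the scatter).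

Compound 3 `CC(=O)Nc1ccc(S(=O)(=O)NNc2ccccc2)cc1` has a different core from compound 1 and compound 2 and is not joined to either by a single-point step. In this assay compound 3 gives only a limit, > 10000 nM. That limit is the assay ceiling, (the limit of > 10000 nM in this assay, at which 1 of the 3 values shown sits), so compound 3 stands at the weak end of the numbers shown, and its distance from the other two compounds is not fixed.

Compound 4 `CC(=O)Nc1ccc(S(=O)(=O)NNc2ccc(C#N)cc2)cc1` is compound 3 with cyano in place of hydrogen on an aromatic carbon. Going by the values given here, the one measured step, from compound 1 to compound 2, changes a different ring and a different kind of group, so it does not bear on this change; no measured step does. Compound 4 is therefore expected to stay near the ceiling, with the step of a number no higher from compound 3 to compound 4 (the limit leaves the size open) carrying no real direction. The estimate for compound 4 is 10000 nM, between 2000 nM and 50000 nM, and another limit rather than a number is the expected outcome.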

Compound 4, half-maximal effective concentration: 1390 nM
Estimate against measurement, compound 4: 7.2-fold (0.86 log units) above; the measured number lies below the stated range.
By their numbers in this assay, from the lowest: compound 1; then compound 4; then compound 2. At a limit, above all of these: compound 3.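

In this assay, cyano in place of hydrogen on an aromatic carbon, para to a large group, gives an at least 7.1-fold lower number from compound 3 to compound 4 (0.85 log units; beyond the scatter). This shows that this position on the six-membered aromatic ring responds to substitution, and that a single added group is enough to bring the core of compound 3 to a measurable value, whereas the earlier step concerned a group on the other aromatic ring. Compound 3 gives only a limit, so this step is a bound and its full size stays unknown: the limit of > 10000 nM in this assay, at which 1 of the 4 values shown sits.

With cyano as the only group shown at this position, the compounds leave open whether the gain is specific to it or would also appear with an amine, a carboxylic acid or a chlorine atom in the same place. They also leave open whether cyano at this position would lower the number on the core of compound 1 to a similar extent, and whether the acetamide group of compound 4 could give way to the (carboxymethyl)carbamoyl group of compound 1 with a further change.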